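A 4-Methylphenyl Group Replaces 3-Bromophenyl

This account rests on a few compounds, and the source may have more. Where it says the series, first, only, none or still open, it means among the compounds named here.

In a functional assay on Ehrlich cells (Mus musculus) for cytotoxicity, read by LDH release, with a stated time of 48 h (on this read-out lower numbers stand for stronger inhibition and higher numbers for weaker inhibition), compound 1 `Cc1ccc(OCC(=O)NNC(=O)c2cc3ccccc3oc2=O)c(C(=O)c2ccccc2Br)c1` gives 9400 nM as its reading. Compound 2 `Cc1ccc(OCC(=O)NNC(=O)c2cc3ccccc3oc2=O)c(C(=O)c2ccccc2Cl)c1` gives 47600 nM and compound 3 `Cc1ccc(OCC(=O)NNC(=O)c2cc3ccccc3oc2=O)c(C(=O)c2cccc(Br)c2)c1` gives 68100 nM on the same scale. Compound 3 sits level with compound 2, with a 1.4-fold higher number from compound 2 to compound 3 (0.16 log units; within the scatter) between them. Among the measured compounds shown here, compound 4 `Cc1ccc(C(=O)c2cc(C)ccc2OCC(=O)NNC(=O)c2cc3ccccc3oc2=O)cc1` carries 4-methylphenyl in place of 3-bromophenyl on a carbonyl carbon as its only change. For the measured compounds named here, no measured step swaps bromo for methyl. The steps beyond the scatter all lead away from compound 1, a 5.1-fold higher number from compound 1 to compound 2 (0.70 log units; beyond the scatter) and a 7.2-fold higher number from compound 1 to compound 3 (0.86 log units; beyond the scatter) among them, and compound 4 lacks its 2-bromophenyl group. The expected step in this assay is therefore a 1.1-fold lower number from compound 3 to compound 4 (0.05 log units; within the scatter) with no direction favoured beyond the scatter. For compound 4 the estimated value is 60000 nM with an expected range from 25000 nM to 140000 nM in this measurement.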

Compound 4, half-maximal inhibitory concentration: 81400 nM
The estimate for compound 4 lay 1.4-fold (0.13 log units) below the measured number; low and high end bracket the measured number.
By their numbers in this assay, from the lowest: compound 1; then compounds 2, 3 and 4 (each within the scatter of the next).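

In this assay, 4-methylphenyl on the carbonyl carbon reads level with 3-bromophenyl, a 1.2-fold higher number from compound 3 to compound 4 (0.08 log units; within the scatter), and with 2-chlorophenyl, a 1.7-fold higher number from compound 2 to compound 4 (0.23 log units; within the scatter), so a ring with no halogen sits in the same range as two rings that carry one. Only 2-bromophenyl stands apart, an 8.7-fold higher number from compound 1 to compound 4 (0.94 log units; beyond the scatter), which makes compound 1 the one exception among these four compounds. No available evidence bears on what sets compound 1 apart. On these data alone, whether a phenyl ring carrying an amine or a carboxylic acid at this place would read nearer compound 1 or nearer the other three stays open.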